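Small versus large groups on the amide nitrogen

The source may hold more compounds than are shown below. What is called first, only, known or untested is meant among the compounds shown, and "the series" means these compounds.

compound 1 `CCN(Cc1cccs1)C(=O)COc1ccc(C)cc1`: 8 nM in an assay on HEK293 cells for agonist activity at transient receptor potential cation channel subfamily M member 8 (Homo sapiens), read by fluorescence and calcium flux, with a stated time of 15 min; on this read-out lower numbers stand for an effect already at smaller amounts and higher numbers for an effect only at larger amounts of compound
compound 2 `Cc1ccc(OCC(=O)N(Cc2cccs2)C2CCCCC2)cc1`: 40000 nM

Among the compounds with values here, compound 2 holds the highest of the two numbers measured; its only neighbour is compound 1, separated by a 5000-fold higher number from compound 1 to compound 2 (3.70 log units; beyond the scatter). Compound 3 `CON(Cc1cccs1)C(=O)COc1ccc(C)cc1` differs from compound 2 by methoxy in place of cyclohexyl on an amide-type nitrogen. That single measured step bears directly on this change: removing the cyclohexyl again, now for a two-heavy-atom group comparable in size to the ethyl of compound 1, is expected to reverse most of that large step, returning the number toward compound 1 rather than leaving it unchanged within the scatter. The expected step is a 1300-fold lower number from compound 2 to compound 3 (3.12 log units; beyond the scatter). Compound 3 is accordingly estimated at 30 nM in this assay, with a range from 5 nM to 400 nM.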

Compound 3, half-maximal effective concentration: 10 nM
Beside the measured number, compound 3's estimate is 3.0-fold (0.48 log units) above it; measured number inside the range.
By their numbers in this assay, from the lowest: compounds 1 and 3 (each within the scatter of the next); then compound 2.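

Swapping cyclohexyl for methoxy on the amide-type nitrogen gives a 4000-fold lower number from compound 2 to compound 3 (3.60 log units; beyond the scatter) in this assay, so the large step seen earlier is not tied to ethyl alone. Methoxy and ethyl cannot be told apart at this position, with a 1.3-fold higher number from compound 1 to compound 3 (0.10 log units; within the scatter), even though methoxy brings an oxygen and a hydrogen-bond acceptor. Nothing available explains the difference between these groups. As far as these compounds go, it remains open whether isopropyl or cyclopropyl on this nitrogen stays with compounds 1 and 3 or moves toward compound 2, and how a hydroxy group would fare here.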